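Swapping the sulfonyl heteroaryl: expectation for compound 4

The compounds below may be only part of what the source reports. "The series", "measured", "known", "first", "only" and "open" are said of these compounds alone.

Compound 1 `Cc1ccc2[nH]c(C(=O)N[C@H]3CN(S(=O)(=O)c4cccnc4)C[C@@H]3C(=O)NCCN(C)C)cc2c1` gives 8 uL/min in an ADME assay on cells (Hepatocyte, Rattus norvegicus) for metabolic stability; on this read-out higher numbers stand for fast clearance and lower numbers for slow clearance.
Compound 2 `Cc1ccc2[nH]c(C(=O)N[C@H]3CN(S(=O)(=O)c4cnccn4)C[C@@H]3C(=O)NCCN(C)C)cc2c1` gives 12 uL/min.
Compound 3 `Cc1ccc2[nH]c(C(=O)N[C@H]3CN(S(=O)(=O)c4ccnc(C)c4)C[C@@H]3C(=O)NCCN(C)C)cc2c1` gives 8 uL/min.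

All three swaps of the ring on the sulfonyl sulfur stayed within the scatter: a 1.5-fold higher number from compound 1 to compound 2 (0.18 log units; within the scatter), no change at the digits printed from compound 1 to compound 3 (within the scatter), a 1.5-fold lower number from compound 2 to compound 3 (0.18 log units; within the scatter). Compound 3 therefore stands level with compound 1, the two together the lowest of the three numbers, with compound 2 the furthest from it.

Compound 4 `Cc1ccc2[nH]c(C(=O)N[C@H]3CN(S(=O)(=O)c4cn(C)nc4C)C[C@@H]3C(=O)NCCN(C)C)cc2c1` differs from compound 3 by 1,3-dimethyl-1H-pyrazol-4-yl in place of 2-methylpyridin-4-yl on a sulfonyl sulfur. The three measured steps bear directly on this change, since each likewise exchanged the ring on the sulfonyl sulfur, and none moved beyond the scatter. Compound 4 is therefore expected to stay close to compound 3, with a step of a 1.1-fold higher number from compound 3 to compound 4 (0.05 log units; within the scatter) expected. Compound 4 is estimated at 9 uL/min, within 4 uL/min to 20 uL/min.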

Compound 4, intrinsic clearance in a liver preparation (reported as CLH), per the amount of preparation that the assay uses: 4 uL/min
The estimate for compound 4 lay 2.3-fold (0.35 log units) above the measured number; the range from low to high includes it.
By their numbers in this assay, from the lowest: compounds 4, 1, 3 and 2 (each within the scatter of the next, the first and the last beyond it).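

Going by these compounds alone, with 1,3-dimethyl-1H-pyrazol-4-yl on the sulfonyl sulfur, this assay shows the first step at this position that lies beyond the scatter (a 3.0-fold lower number from compound 2 to compound 4 (0.48 log units; beyond the scatter)), though a modest one. The other two steps stay within the scatter (a 2.0-fold lower number from compound 3 to compound 4 (0.30 log units; within the scatter); a 2.0-fold lower number from compound 1 to compound 4 (0.30 log units; within the scatter)), so the ring exchange separates only compound 2 from compound 4. No measurement available here accounts for this step. Left open is how a plain phenyl ring, or a ring carrying an amine or a carboxylic acid, would read on this sulfonyl sulfur.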